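Octadecyl amide with a pentadienoyl cap: expected cytotoxicity

The source may report more compounds than this note shows. Statements on the series, on what has been measured and on what is new or still open speak of the compounds shown alone.

Two compounds were measured in a functional assay on HepG2 cells (Homo sapiens) for cytotoxicity, read by MTT assay, with a stated time of 48 h; on this read-out lower numbers stand for stronger inhibition and higher numbers for weaker inhibition:
compound 1, `C/C=C/C=C/C(=O)N[C@H](C(=O)NCCCCCCCC)[C@@H](C)O`, 102000 nM
compound 2, `CCCCCCCCCCCCCCCCCCNC(=O)[C@@H](NC(=O)c1cc2ccccc2o1)[C@@H](C)O`, > 200000 nM

Compound 2 sits at the limit of > 200000 nM in this assay, at which 1 of the 2 values shown sits, a limit and not a number. Compound 3 `C/C=C/C=C/C(=O)N[C@H](C(=O)NCCCCCCCCCCCCCCCCCC)[C@@H](C)O` differs from compound 2 by penta-1,3-dien-1-yl in place of 1-benzofuran-2-yl on a carbonyl carbon. Compound 1 carries the same penta-1,3-dien-1-yl carbonyl on an octyl chain and gives 102000 nM. Within the data shown here, no measured step links the two capping groups, so the estimate implies a step of an at least 1.3-fold lower number from compound 2 to compound 3 (0.12 log units; that floor lies within the scatter), read as weak and uncertain. Compound 3 is expected at 150000 nM, between 50000 nM and 400000 nM.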

Compound 3, half-maximal inhibitory concentration: 284000 nM
Compound 3: the middle estimate sits 1.9-fold (0.28 log units) below what was measured, within the range that was stated.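

Among these compounds, with the (penta-1,3-dien-1-yl)carbonyl cap held fixed, this assay gives the first readable step at the chain: decyl in place of hydrogen on a saturated chain carbon, eight bonds along the chain from an amide-type nitrogen, gives a 2.8-fold higher number from compound 1 to compound 3 (0.44 log units; beyond the scatter). The longer chain therefore reads as weaker here, on this single pair. The step between the two caps cannot be read, as compound 2 stands at a limit and not a number: the limit of > 200000 nM in this assay, at which 1 of the 3 values shown sits.

As far as these compounds go, what a hexyl chain or a chain bearing a carboxylic acid would give stays open. So does how the (1-benzofuran-2-yl)carbonyl cap on an octyl chain would compare with compound 1.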